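A few compounds are considered here, and "the series" means these few. Any claim that something is new, unique, unknown or untested is made for them only; others in the source may bear on it.

The measured compounds:

- compound 1, `O=C(/C=C/c1ccccc1)NS(=O)(=O)c1ccc(F)cc1`, giving 2.1 ug/mL
- compound 2, `O=C(/C=C/c1ccccc1)NS(=O)(=O)c1ccc(Cl)cc1`, giving 2.2 ug/mL
- compound 3, `O=C(/C=C/c1ccc(F)cc1)NS(=O)(=O)c1ccccc1`, giving 2.1 ug/mL

These numbers come from a functional assay on B16-F10 cells (Mus musculus) for antiproliferative activity, read by ELISA and MTT assay, with a stated time of 48 h; on this read-out lower numbers stand for stronger inhibition and higher numbers for weaker inhibition. Compound 1 and compound 2 share one core and differ in a single place: chloro in place of fluoro on an aromatic carbon. That exchange made a 1.0-fold higher number from compound 1 to compound 2 (0.02 log units; within the scatter), so the two results are effectively the same. Compound 3 is built from the same atoms as compound 1, joined differently; the difference between the two cores is not broken down here. In this assay compound 3 gives 2.1 ug/mL, which sits level with compound 1 at the digits reported and lies within the scatter of compound 2 as well.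

The next compound, compound 4, `O=C(/C=C/c1ccc(Cl)cc1)NS(=O)(=O)c1ccccc1`, has not yet been measured. It relates to compound 3 in the way compound 2 relates to compound 1: chloro in place of fluoro on an aromatic carbon. The surroundings of the exchange read the same word for word in both pairs, so this is the same change carried onto a second core. Within the data shown here, the only guide to its effect is the earlier pair, where the same exchange gave a 1.0-fold higher number from compound 1 to compound 2 (0.02 log units; within the scatter). On that basis the expected step is a 1.0-fold higher number from compound 3 to compound 4 (0.02 log units; within the scatter), about the size of the earlier one. Compound 4 is therefore expected to give about 2.2 ug/mL in this assay, with a likely range from 1.3 ug/mL to 3.8 ug/mL.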

Compound 4, half-maximal inhibitory concentration: 2.2 ug/mL
Beside the measured number, compound 4's estimate shows no gap at the digits printed, within the range that was stated.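

In this assay, the exchange of chloro for fluoro on the second core gives a 1.0-fold higher number from compound 3 to compound 4 (0.02 log units; within the scatter), so the 4-fluorophenyl and 4-chlorophenyl forms of this core cannot be told apart. The exchange reads the same on the two cores, and the two steps agree: the same change on two cores in this assay, a 1.0-fold higher number (0.02 log units; within the scatter) from compound 1 to compound 2 and a 1.0-fold higher number (0.02 log units; within the scatter) from compound 3 to compound 4, 1.0-fold (0.00 log units) apart, within the scatter of two such steps

This agreement does show that, for these two cores in this one assay, the swap between these two halogens leaves the result within the usual spread of repeated measurements, but it is an agreement between two steps that are each too small to tell from scatter, so it does not show that a real, measurable effect carries from one core to the other, and it says nothing about cores beyond these two.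

The compounds shown leave open whether this position responds at all to a group other than these two halogens, such as a methoxy group, a nitrile, an amine or a carboxylic acid, or to plain hydrogen on that carbon. They also leave open whether the same exchange would stay this small in a different cell line or assay.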